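The source may report more compounds than this note shows. Statements on the series, on what has been measured and on what is new or still open speak of the compounds shown alone.

Compound 1 `O=C(Nc1cc(Cl)cc(Cl)c1)c1cccc(Nc2ncc(F)c(Nc3ccc(F)cc3)n2)c1` gives 17500 nM in a functional assay on A549 cells (Homo sapiens) for antiproliferative activity, read by sulforhodamine B assay, with a stated time of 3 days (a higher number here means a weaker inhibitor of growth, a lower number a stronger inhibitor of growth), and stands as the higher of the two numbers shown. Compound 3 `O=C(Nc1cccc(Nc2ncc(F)c(Nc3ccc(F)cc3)n2)c1)c1cnccn1` gives 10300 nM in this assay, a step of a 1.7-fold lower number from compound 1 to compound 3 (0.23 log units; within the scatter). Compound 2 `O=C(Nc1ccc(C(F)(F)F)cc1)c1cccc(Nc2ncc(F)c(Nc3ccc(F)cc3)n2)c1` returns only a limit in this assay, > 10000 nM, so the step that the limit leaves unreadable from compound 1 to compound 2 cannot be sized; (the limit of > 10000 nM in this assay, at which 1 of the 3 values shown sits).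

Compound 4 `CN1CCC(C(=O)Nc2cccc(Nc3ncc(F)c(Nc4ccc(F)cc4)n3)c2)CC1` differs from compound 1 by ((1-methylpiperidin-4-yl)carbonyl)amino in place of (3,5-dichlorophenyl)carbamoyl on an aromatic carbon. The step that bears on this site, a 1.7-fold lower number from compound 1 to compound 3 (0.23 log units; within the scatter), also exchanges the (3,5-dichlorophenyl)carbamoyl group for a carbonylamino group and stays within the scatter, so no step beyond the scatter is expected here either. Compound 4 is therefore estimated at 12000 nM in this assay, within 3000 nM to 45000 nM, an expected step of a 1.5-fold lower number from compound 1 to compound 4 (0.16 log units; within the scatter).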

Compound 4, concentration for 50% growth inhibition: 1330 nM
Estimate against measurement, compound 4: 9.0-fold (0.96 log units) above; the measured number lies below the stated range.
By their numbers in this assay, from the lowest: compound 4; then compounds 3 and 1 (each within the scatter of the next).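

Among these compounds, at this position, ((1-methylpiperidin-4-yl)carbonyl)amino is the first change to move the number in this assay beyond the scatter, with a 13-fold lower number from compound 1 to compound 4 (1.12 log units; beyond the scatter). With the carbonylamino link held constant, 1-methylpiperidin-4-yl in place of pyrazin-2-yl gives a 7.7-fold lower number from compound 3 to compound 4 (0.89 log units; beyond the scatter), so the link alone does not account for the gain. Nothing measured here gives a cause for these steps.

Still open, going by these compounds, is which part of the non-aromatic ring carries the gain. A piperidin-4-yl group without the methyl, or a cyclohexyl group, on the same carbonyl would separate the methyl and the ring nitrogen from the ring itself.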